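The source may report more compounds than this note shows. Statements on the series, on what has been measured and on what is new or still open speak of the compounds shown alone.

Compound 1, `Cc1cccc(-c2nc(CNc3ccc(C(=O)NO)cc3)n(-c3ccccc3)n2)c1`, gives 64.1% in an assay on Sf9 cells for inhibition of protein deacetylase HDAC6 (Homo sapiens), read by fluorescence, with a stated time of 40 min, tested at 100 nM; a lower number here means less inhibition, a higher number more inhibition at the concentration tested (going by the name of the read-out).
Compound 2, `O=C(NO)c1ccc(NCc2nc(-c3ccccc3)nn2-c2ccc(Cl)cc2)cc1`, gives 55.4% in this assay.

These two compounds share one core and differ only in the groups attached to it. Compound 1 holds the larger of the two numbers in this assay, yet the gap to compound 2 is within the usual scatter of repeated measurements, so the two results count as level and neither number can be called the higher.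

The next compound, compound 3, is `CC(C)c1ccc(-c2nc(CNc3ccc(C(=O)NO)cc3)n(-c3ccccc3)n2)cc1`. Its change from compound 1 is 4-isopropylphenyl in place of 3-methylphenyl on an aromatic carbon. For the measured compounds named here, no pair of measured compounds differs in just one place, so nothing measured so far shows how a change of this kind on that aromatic carbon moves the read-out. Going by the values given here, the only guide is that two related compounds with different groups sit within the scatter of each other. The step from compound 1 to compound 3 is therefore expected to stay within the scatter, with no clear direction, as a number 4.1 percentage points lower from compound 1 to compound 3 (within the scatter).

Compound 3 is estimated to give 60% in this assay, with a range from 40% to 80%.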

Compound 3, a percentage reported as inhibition, at one concentration (the size of the read-out at that concentration, not a potency): 27.6%
For compound 3 the middle estimate is 32.4 percentage points above the measured one; the measured number lies below the stated range.
By their numbers in this assay, from the lowest: compound 3; then compounds 2 and 1 (each within the scatter of the next).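

In this assay, for the compounds shown here, putting 4-isopropylphenyl in place of 3-methylphenyl on this aromatic carbon of the shared core gives a number 36.5 percentage points lower from compound 1 to compound 3 (beyond the scatter), a large step and the first measured between compounds that differ in one place. It shows that the read-out responds strongly to the group held at this carbon, the one lying between two ring nitrogen atoms. The two groups are not interchangeable here, even though each has one six-membered aromatic ring of carbon only, with no hydrogen-bond donors or acceptors and no net charge. Nothing available explains this drop.

This single step changes two things at once: the small group on the phenyl ring and the place it occupies there, so the compounds shown cannot separate the two; 3-isopropylphenyl and 4-methylphenyl would tell them apart. Also open, on these data alone, is how this carbon would respond to a different kind of group altogether, such as a phenyl ring carrying an amine or a carboxylic acid, or a longer chain with no ring at all.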